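The source may report more compounds than this note shows. Statements on the series, on what has been measured and on what is new or still open speak of the compounds shown alone.

Working notes on the sulfonamide series, read in a physicochemical assay for solubility, in phosphate buffer, measured as kinetic solubility, at pH 7.4; on this read-out lower numbers stand for lower solubility and higher numbers for higher solubility.

Compound 1 `CN(C)S(=O)(=O)c1ccc2c(c1)/C(=C1/Nc3ccccc3/C1=N\O)C(=O)N2` reaches only a limit of the assay in this assay, reported as < 1 ug/mL. Compound 3 `CN(C)S(=O)(=O)c1ccc2c(c1)/C(=C1/Nc3ccccc3C1=O)C(=O)N2` likewise gives only a limit in this assay, < 1 ug/mL. Compound 2 `C=CCC1(O)/C(=C2/C(=O)Nc3ccc(S(=O)(=O)N(C)CCN(C)C)cc32)Nc2ccccc21` stands at the opposite end: in this assay compound 2 returns a limit as well, > 40 ug/mL, so no number is known for it, only that it lies at the upper boundary of the read-out. For the measured compounds named here, two of the three results therefore sit at the lower boundary the limit of < 1 ug/mL in this assay, at which 2 of the 3 values shown sit, and one at the upper boundary (the limit of > 40 ug/mL in this assay, at which 1 of the 3 values shown sits); no pair of measured compounds differs in a single place, so no measured step can be stated, and compound 2 is merely the one whose limit is at the high end while compound 1 and compound 3 sit at the low end.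

Compound 4 `C=CCC1(O)/C(=C2/C(=O)Nc3ccc(S(=O)(=O)N(C)C)cc32)Nc2ccccc21` is the next member to be measured. Its change from compound 2 is hydrogen in place of (dimethylamino)methyl on a saturated chain carbon bound to a sulfonamide nitrogen. The expected step from compound 2 to compound 4 is an at least 8.0-fold lower number from compound 2 to compound 4 (0.90 log units; beyond the scatter), a decrease in solubility beyond the usual scatter. Compound 4 is expected to give 5 ug/mL, with a range from 1 ug/mL to 30 ug/mL, and the outcome may again be reported as a limit rather than a number.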

Compound 4, solubility: 31 ug/mL
Compound 4: the middle estimate sits 6.2-fold (0.79 log units) below what was measured; the measured number lies above the stated range.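

In this assay, for the compounds shown here, compound 4 gives 31 ug/mL, a number rather than a limit of the assay, which none of the earlier compounds supplied. Hydrogen in place of (dimethylamino)methyl on a saturated chain carbon bound to a sulfonamide nitrogen gives an at least 1.2-fold lower number from compound 2 to compound 4 (0.11 log units; that floor lies within the scatter), and this change leaves the read-out clear of its lower limit for this pair. Only this floor can be stated, since the result for compound 2 is itself a limit of the assay: the limit of > 40 ug/mL in this assay, at which 1 of the 4 values shown sits.

From the compounds shown here alone, the true size of the step stays open: it may lie within the scatter or well beyond it, and a single pair at a single place says nothing general about this chain. Also open, going by these compounds, is how a carboxylic acid or a morpholine at the end of the chain, or a longer chain ending in the same dimethylamino group, would read in this assay.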